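Tert-butyl to methyl on the oxazole amide

The source may hold more compounds than are shown below. What is called first, only, known or untested is meant among the compounds shown, and "the series" means these compounds.

Three amides on the shared core have been run in an assay on isolated protein for inhibition of Rho-associated protein kinase 2 (Homo sapiens), read by scintillation counting, radiometric assay and 33P incorporation, with a stated time of 40 min, in the presence of a further agent that is not named here; on this read-out lower numbers stand for stronger inhibition and higher numbers for weaker inhibition. Compound 1 `CCc1ccc(C(=O)Nc2cccc(NC(=O)COc3ccc4c(=O)ccoc4c3)c2)cc1` gives 24 nM, and compound 2 `CCCc1ccc(C(=O)Nc2cccc(NC(=O)COc3ccc4c(=O)ccoc4c3)c2)cc1` gives 14 nM; the step of a 1.7-fold lower number from compound 1 to compound 2 (0.23 log units; within the scatter) is a chain extension by one carbon. Compound 3 `CC(C)(C)c1cc(C(=O)Nc2cccc(NC(=O)COc3ccc4c(=O)ccoc4c3)c2)no1` gives 5 nM, the lowest of the three numbers, with a 4.8-fold lower number from compound 1 to compound 3 (0.68 log units; beyond the scatter) and a 2.8-fold lower number from compound 2 to compound 3 (0.45 log units; beyond the scatter) both beyond the scatter.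

Compound 4 `Cc1cc(C(=O)Nc2cccc(NC(=O)COc3ccc4c(=O)ccoc4c3)c2)no1` is compound 3 with methyl in place of tert-butyl on an aromatic carbon. For the measured compounds named here, no measured step trims this group; the only change in size of an alkyl substituent on file is the extension from compound 1 to compound 2, which stayed within the scatter. On that basis the loss of three carbons from the tert-butyl is expected to cost little, with a slight shift toward a higher number allowed but not beyond the scatter, so the expected step is a 1.8-fold higher number from compound 3 to compound 4 (0.26 log units; within the scatter) in this assay. Compound 4 is therefore estimated at 9 nM, with a range from 4 nM to 25 nM.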

Compound 4, half-maximal inhibitory concentration: 5 nM
The estimate for compound 4 lay 1.8-fold (0.26 log units) above the measured number, within the range that was stated.
By their numbers in this assay, from the lowest: compounds 3 and 4 (each within the scatter of the next); then compounds 2 and 1 (each within the scatter of the next).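

On the aromatic carbon next to the ring oxygen, tert-butyl to methyl gives no change at the digits printed from compound 3 to compound 4 (within the scatter) in this assay, so in this series methyl serves there as well as tert-butyl. The advantage of the oxazole amide over the two alkylphenyl amides therefore does not require tert-butyl: 5-methyl-1,2-oxazol-3-yl also gives a 2.8-fold lower number from compound 2 to compound 4 (0.45 log units; beyond the scatter) and a 4.8-fold lower number from compound 1 to compound 4 (0.68 log units; beyond the scatter). No supporting measurement is available to explain why the two groups read alike.

Still open, going by these compounds, is how far this tolerance extends, for instance to hydrogen, an amine or a carboxylic acid on the same aromatic carbon. The compounds shown also leave open whether compound 3 and compound 4 would stay level against any kinase other than the one tested here.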